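A few compounds are considered here, and "the series" means these few. Any claim that something is new, unique, unknown or untested is made for them only; others in the source may bear on it.

In an ADME assay on THP-1 cells (Homo sapiens) for cytotoxicity, read by MTT assay (a higher number here means a weaker inhibitor, a lower number a stronger inhibitor), compound 1 (`Fc1ccc(-c2nc(C(Cl)(Cl)Cl)nc3ccccc23)cc1`) gives 125000 nM as its reading. Compound 3 (`FC(F)(F)c1cccc(-c2nc(C(Cl)(Cl)Cl)nc3ccccc23)c1`) gives 78600 nM in the same test, and these two numbers lie within the usual scatter of each other, so neither can be ranked ahead of the other. Compound 2 (`COc1cc(-c2nc(C(Cl)(Cl)Cl)nc3ccccc23)cc(OC)c1OC`) gives only a limit of the assay, > 250000 nM in place of an exact number.

Compound 4 (`COc1ccc(-c2nc(C(Cl)(Cl)Cl)nc3ccccc23)cc1`) has not been measured yet. It keeps the core of compound 1 and changes one group: methoxy in place of fluoro on an aromatic carbon, para to a large group (methoxy in place of fluoro on an aromatic carbon).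

Going by the values given here, no two measured compounds differ in just one place, so there is no direct guide to this swap. Among the compounds with values here, compound 2 is the only measured compound that carries methoxy groups, and it stays at its limit of > 250000 nM in this test. Starting from compound 1 at 125000 nM the single swap is expected to bring no step beyond the scatter in this assay with a slight lean towards a higher number. The estimated move (a 1.1-fold higher number from compound 1 to compound 4 (0.05 log units; within the scatter)) is therefore a small one. For compound 4 the expected value is 140000 nM with an estimated range from 70000 nM to 250000 nM in this test.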

Compound 4, half-maximal inhibitory concentration: 250000 nM
Compound 4: middle estimate off by 1.8-fold (0.25 log units), on the low side; the range from low to high includes it.
By their numbers in this assay, from the lowest: compounds 3, 1 and 4 (each within the scatter of the next, the first and the last beyond it).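

Going by these compounds alone, this is the first direct look at a single change in this set: methoxy in place of fluoro on an aromatic carbon, para to a large group, gives a 2.0-fold higher number from compound 1 to compound 4 (0.30 log units; within the scatter). In this assay, therefore, this swap brings no difference that can be told apart from the ordinary spread of repeat measurements, even though the entering group has one more heavy atom than fluoro and adds a hydrogen-bond acceptor. The reading of compound 4 also sits at the same figure as the one value in this set that is a limit of the assay rather than a number, so a further rise from this compound could not be followed far in this test: the limit of > 250000 nM in this assay, at which 1 of the 4 values shown sits.

One swap at one position cannot show whether this place on the ring responds to change at all, or whether fluoro and methoxy simply happen to read alike. An amine, a carboxylic acid or a longer chain such as ethoxy at the same place would test this, and any of them could show whether a step beyond the scatter is possible there.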